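This account rests on a few compounds, and the source may have more. Where it says the series, first, only, none or still open, it means among the compounds named here.

In a functional assay on MCF7 cells (Homo sapiens) for cytotoxicity, read by MTT assay, with a stated time of 72 h (a higher number here means a weaker inhibitor, a lower number a stronger inhibitor), compound 1 `COc1cccc(/C=C2\CCC/C(=C\c3ccc(Cl)cc3)C2=O)c1OC` gives 10300 nM and compound 2 `COc1cccc(/C=C2\CCC/C(=C\c3cccc(OC)c3OC)C2=O)c1` gives 5900 nM. Compound 3 `COc1cccc(/C=C2\CCC/C(=C\c3ccc(O)cc3)C2=O)c1OC` has no number, only a limit of the assay: > 20000 nM. Compound 4 `COc1cccc(/C=C2\CCC/C(=C\c3ccc(O)c(Cl)c3)C2=O)c1OC` differs from compound 3 by one change, chloro in place of hydrogen on an aromatic carbon, ortho to a hydroxy group. Among the compounds with values here, no measured step makes exactly this change. The closest is an at least 1.9-fold higher number from compound 1 to compound 3 (0.28 log units; that floor lies within the scatter), where hydroxy replaces chloro, and an at least 3.3-fold higher number from compound 2 to compound 3 (0.53 log units; beyond the scatter) also ends at the same limit. Adding a chloro back is therefore expected to lower the number modestly. The estimated step is an at least 1.8-fold lower number from compound 3 to compound 4 (0.25 log units; that floor lies within the scatter). For compound 4 the estimated value is 11000 nM, within a range of 4500 nM to 20000 nM.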

Compound 4, half-maximal inhibitory concentration: 16400 nM
Compound 4: the middle estimate sits 1.5-fold (0.17 log units) below what was measured; the measured number falls inside the stated range.
By their numbers in this assay, from the lowest: compounds 2, 1 and 4 (each within the scatter of the next, the first and the last beyond it). At a limit, above all of these: compound 3.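

In this assay, chloro ortho to a hydroxy group gives a measurable number, with an at least 1.2-fold lower number from compound 3 to compound 4 (0.08 log units; that floor lies within the scatter). Compound 3 stands only at a limit, so the true size of that step stays open: the limit of > 20000 nM in this assay, at which 1 of the 4 values shown sits.

Against the 3-methoxyphenyl group, the 3-chloro-4-hydroxyphenyl group shows a 2.8-fold higher number from compound 2 to compound 4 (0.44 log units; beyond the scatter), and against the 4-chlorophenyl group it shows a 1.6-fold higher number from compound 1 to compound 4 (0.20 log units; within the scatter). As far as these compounds go, what a fluoro, a methyl or an amine would do in the same place, ortho to a hydroxy group, remains open.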